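Swapping methyl for chloro on the shared core

A few compounds are considered here, and "the series" means these few. Any claim that something is new, unique, unknown or untested is made for them only; others in the source may bear on it.

Compound 1 `CN1CCN(CC(=O)N[C@]2(c3ccc(Cl)cc3)C(=O)Nc3cc(Cl)c(Cl)cc32)CC1`: 249 nM
Compound 2 `CCN1CCN(CC(=O)NC2(c3ccc(Cl)cc3)C(=O)Nc3cc(Cl)c(C)cc32)CC1`: 286 nM

In an in vitro assay on CHO-CREluc cells for displacement of a labelled ligand from growth hormone secretagogue receptor type 1 (Homo sapiens), read by scintillation counting, with a stated time of 1 h (a higher number here means a weaker inhibitor, a lower number a stronger inhibitor), compound 1 gives 249 nM. In this assay, for the measured compounds named here, compound 2 gives 286 nM, a number that sits within the usual scatter of the one for compound 1, so the two cannot be told apart. Compound 3 `CCN1CCN(CC(=O)NC2(c3ccc(Cl)cc3)C(=O)Nc3cc(Cl)c(Cl)cc32)CC1` is not yet measured. It differs from compound 2 by chloro in place of methyl on an aromatic carbon. Going by the values given here, no measured pair shows this change on its own, so there is no yardstick for it here. Given how close compound 1 and compound 2 are, the expected step is a 1.1-fold lower number from compound 2 to compound 3 (0.06 log units; within the scatter), no larger than the scatter. Compound 3 is therefore estimated at 250 nM, between 120 nM and 550 nM.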

Compound 3, inhibition constant: 202 nM
The estimate for compound 3 lay 1.2-fold (0.09 log units) above the measured number; the range from low to high includes it.
By their numbers in this assay, from the lowest: compounds 3, 1 and 2 (each within the scatter of the next).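

Chloro and methyl on this aromatic carbon, ortho to a chloro group, now have a direct comparison: in this assay the exchange gives a 1.4-fold lower number from compound 2 to compound 3 (0.15 log units; within the scatter), so the two groups cannot be told apart at this position. This single pair gives the first yardstick for the change, and it is a step no larger than the scatter. Nothing measured here offers a reason for this result. Going by these compounds, whether plain hydrogen, a methoxy group or a trifluoromethyl group on the same carbon would shift the number stays open. So does whether this exchange would give a similar step at another carbon of the ring.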